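Moving the methyl on the thiophene of compound 3

This account rests on a few compounds, and the source may have more. Where it says the series, first, only, none or still open, it means among the compounds named here.

Compound 3 `Cc1ccc([C@@H]2C[C@H](O)Cc3cc(F)ccc3N2)s1` was tested in an ADME assay on THP-1 cells (Homo sapiens) for cytotoxicity (a lower number here means that less compound is tolerated, a higher number that more compound is tolerated), where compound 3 gives 312000 nM. Among the three measured compounds it holds the second highest number; its nearest neighbour is compound 2 `O[C@@H]1Cc2cc(F)ccc2N[C@H](c2cccs2)C1` with 190000 nM, and the furthest is compound 1 `Cc1ccsc1[C@@H]1C[C@H](O)Cc2ccccc2N1` with 579000 nM, both within the scatter of compound 3. Among the compounds with values here, the only step recorded among them, a 1.6-fold higher number from compound 2 to compound 3 (0.22 log units; within the scatter), concerns a methyl in place of hydrogen on an aromatic carbon and stays inside the scatter.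

Compound 4 `Cc1ccsc1[C@@H]1C[C@H](O)Cc2cc(F)ccc2N1` differs from compound 3 by 3-methylthiophen-2-yl in place of 5-methylthiophen-2-yl on a saturated ring carbon. Within the data shown here, no measured step covers this rearrangement directly. Compound 1 carries the same 3-methylthiophen-2-yl but lacks the fluorine, and its number stands within the scatter of compound 3, so the two thiophene patterns have so far given no separable result. The methyl step between compound 2 and compound 3 also fell within the scatter. On this basis compound 4 is expected to move by a 1.3-fold higher number from compound 3 to compound 4 (0.11 log units; within the scatter) in this assay, a change that is not expected to exceed the scatter. Compound 4 is therefore estimated at 400000 nM, with a range from 200000 nM to 800000 nM.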

Compound 4, half-maximal cytotoxic concentration: 1810000 nM
Compound 4: middle estimate off by 4.5-fold (0.66 log units), on the low side; the whole stated range lies below it.
By their numbers in this assay, from the lowest: compounds 2, 3 and 1 (each within the scatter of the next, the first and the last beyond it); then compound 4.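

In this assay, the place of the methyl on the thiophene now separates the two patterns: 3-methylthiophen-2-yl in place of 5-methylthiophen-2-yl on the saturated ring carbon gives a 5.8-fold higher number from compound 3 to compound 4 (0.76 log units; beyond the scatter), the first step among these compounds to lie beyond the scatter. Starting from the unmethylated thiophene, the methyl in the 5-methylthiophen-2-yl pattern gave only a 1.6-fold higher number from compound 2 to compound 3 (0.22 log units; within the scatter), whereas the methyl in the 3-methylthiophen-2-yl pattern gives a 9.5-fold higher number from compound 2 to compound 4 (0.98 log units; beyond the scatter), so the outcome of adding this methyl depends on where it stands on the ring. With the 3-methylthiophen-2-yl group held constant, adding the fluorine to the shared core also counts, at a 3.1-fold higher number from compound 1 to compound 4 (0.50 log units; beyond the scatter), and nothing available here bears on what lies behind any of these steps.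

The compounds shown leave open whether a longer chain such as ethyl, or a chlorine, in place of the methyl of 3-methylthiophen-2-yl would keep the number given by compound 4 at 1810000 nM. From the compounds shown here alone, the 5-methylthiophen-2-yl group appears here only together with the fluorine, and whether the fluoro step holds for that group also remains open.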